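Formylamino in place of imidazole on the oxazolidinone side chain

This account rests on a few compounds, and the source may have more. Where it says the series, first, only, none or still open, it means among the compounds named here.

Compound 1, `CN1CCN(C[C@H]2CN(c3ccc(-n4cc(-c5ccccn5)cn4)c(F)c3)C(=O)O2)CC1`, gives 2.2 in a physicochemical assay for lipophilicity, read by HPLC, measured as octanol-water partition; on this read-out higher numbers stand for higher lipophilicity and lower numbers for lower lipophilicity. Compound 2, `O=C1CCC(=O)N1C[C@H]1CN(c2ccc(-n3cc(-c4ccccn4)cn3)c(F)c2)C(=O)O1`, gives 1.58 in this assay. Compound 3, `O=C1O[C@@H](Cn2ccnc2)CN1c1ccc(-n2cc(-c3ccccn3)cn2)c(F)c1`, gives 1.73 in this assay.

Among the three measured values, compound 3 stands second highest: the gap between compound 2 and compound 3 is a number 0.15 log units higher from compound 2 to compound 3 (within the scatter), while the other gap is a number 0.47 log units lower from compound 1 to compound 3 (beyond the scatter).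

Compound 4, `O=CNC[C@H]1CN(c2ccc(-n3cc(-c4ccccn4)cn3)c(F)c2)C(=O)O1`, is not yet measured. It differs from compound 3 in one place: formylamino in place of 1H-imidazol-1-yl on a saturated chain carbon bound to a saturated ring carbon.

Among the compounds with values here, the steps that bear on this change are those at the same position. From compound 1 to compound 2 the change was a number 0.62 log units lower from compound 1 to compound 2 (beyond the scatter), and from compound 1 to compound 3 it was a number 0.47 log units lower from compound 1 to compound 3 (beyond the scatter); the two replacements of the methylpiperazinyl group landed within the scatter of each other, as a number 0.15 log units higher from compound 2 to compound 3 (within the scatter) shows. Exchanging one small uncharged group with one acceptor-bearing group for another carrying a donor and an acceptor is therefore expected to move this assay only a little, if at all, and a small decrease is the more likely direction. The estimated step is a number 0.33 log units lower from compound 3 to compound 4 (beyond the scatter). For compound 4 the estimate in this assay is 1.4, with a range from 1 to 1.8.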

Compound 4, partition coefficient: 1.19
Compound 4: the middle estimate sits 0.21 log units above what was measured; the range from low to high includes it.
By their numbers in this assay, from the lowest: compound 4; then compounds 2 and 3 (each within the scatter of the next); then compound 1.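

In this assay, within the data shown here, the position on a saturated chain carbon bound to a saturated ring carbon turns out to separate its groups more widely than the earlier compounds showed. Formylamino, which has no ring, stands clear of both groups that had lain within the scatter of each other: in place of 1H-imidazol-1-yl it gives a number 0.54 log units lower from compound 3 to compound 4 (beyond the scatter) and in place of 2,5-dioxopyrrolidin-1-yl it gives a number 0.39 log units lower from compound 2 to compound 4 (beyond the scatter) as the second step. Measured against 4-methylpiperazin-1-yl, the same group gives a number 1.01 log units lower from compound 1 to compound 4 (beyond the scatter) and so provides the only large step at this position among the compounds shown, while no measurement shown offers a reason for any of these steps.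

The change from 1H-imidazol-1-yl to formylamino removes a ring and adds a hydrogen-bond donor at once, so these compounds cannot say which of the two differences goes with the lower number. Going by these compounds, how this assay would read with acetylamino, a primary amine or a carboxylic acid on the same chain carbon also stays open.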